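Phenyl for Thiophene: Expected Cytotoxicity of Compound 3

A few compounds are considered here, and "the series" means these few. Any claim that something is new, unique, unknown or untested is made for them only; others in the source may bear on it.

Compound 1 `Oc1cccc(-c2cc(-c3ccc(Cl)cc3)nc(-c3cccs3)c2)c1`: 9280 nM
Compound 2 `Oc1ccc(-c2cc(-c3ccc(Cl)cc3)nc(-c3cccs3)c2)cc1`: 6470 nM

In a functional assay on HCT-15 cells (Homo sapiens) for cytotoxicity, read by CCK-8 assay and cell counting, with a stated time of 2 days (a higher number here means a weaker inhibitor, a lower number a stronger inhibitor), compound 1 gives 9280 nM and compound 2 gives 6470 nM. Among the measured compounds shown here, the only measured step, a 1.4-fold lower number from compound 1 to compound 2 (0.16 log units; within the scatter), concerns the hydroxyphenyl group, not the thiophen-2-yl group, and compound 2 lies within the scatter of compound 1. Compound 3 `Oc1ccc(-c2cc(-c3ccccc3)nc(-c3ccc(Cl)cc3)c2)cc1` differs from compound 2 by phenyl in place of thiophen-2-yl on an aromatic carbon. For the measured compounds named here, no measured step bears on this exchange, so nothing beyond the scatter is expected in this assay. Compound 3 is estimated at 6500 nM, with a range of 2500 nM to 17000 nM. The expected step is therefore a 1.0-fold higher number from compound 2 to compound 3 (0.00 log units; within the scatter).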

Compound 3, half-maximal inhibitory concentration: 6920 nM
Compound 3: middle estimate off by 1.1-fold (0.03 log units), on the low side, and the stated range covers the measured number.
By their numbers in this assay, from the lowest: compounds 2, 3 and 1 (each within the scatter of the next).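

In this assay, phenyl in place of thiophen-2-yl next to the ring nitrogen gives a 1.1-fold higher number from compound 2 to compound 3 (0.03 log units; within the scatter), so compound 2 and compound 3 stand within the scatter of each other. At this position, the ring sulfur of thiophen-2-yl is therefore dispensable for this level of cytotoxicity, and a six-membered aromatic ring of carbon only serves equally well. No available evidence accounts for this result.

Still open, from the compounds shown here alone, is whether an amine, a carboxylic acid or a longer alkyl chain at this position would stay within the scatter. The compounds shown also leave open whether a methoxy group on the entering phenyl would alter the number.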